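Chloromethyl in place of fluorophenyl on a shared core

The source may hold more compounds than are shown below. What is called first, only, known or untested is meant among the compounds shown, and "the series" means these compounds.

Compound 1, `Nc1nn2c(O)cc(-c3ccccc3F)nc2c1[N+](=O)[O-]`: in a functional assay on K562 cells (Homo sapiens) for inhibition (on this read-out lower numbers stand for stronger inhibition of growth and higher numbers for weaker inhibition of growth), compound 1 gives > 50 ug/mL, a limit of the assay.
Compound 2, `Nc1nn2c(O)cc(-c3ccc(F)cc3)nc2c1[N+](=O)[O-]`: in this assay compound 2 gives > 50 ug/mL, likewise a limit.

Compound 2 thus stands at the limit (the limit of > 50 ug/mL in this assay, at which 2 of the 2 values shown sit), not at a number. The step that the two limits leave unreadable from compound 1 to compound 2 is left unreadable by the two limits. Compound 3, `Nc1nn2c(O)cc(CCl)nc2c1[N+](=O)[O-]`, differs from compound 2 by chloromethyl in place of 4-fluorophenyl on an aromatic carbon. For the measured compounds named here, no measured step bears on this change. Compound 3 is therefore estimated at 50 ug/mL, within 15 ug/mL to 150 ug/mL, and the expected step is a number no higher from compound 2 to compound 3 (the limit leaves the size open), with a further limit the most likely outcome.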

Compound 3, concentration for 50% growth inhibition: > 50 ug/mL
Compound 3 gave a limit, no number; the forecaster's own chance of this, stated with the estimate: 65%; the middle value lies on the limit itself.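

No step can be read among compound 1, compound 2 and compound 3, for each gives only a limit: the limit of > 50 ug/mL in this assay, at which 3 of the 3 values shown sit. The compounds shown leave open how 2-fluorophenyl, 4-fluorophenyl and chloromethyl rank in this assay on the shared core.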